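A few compounds are considered here, and "the series" means these few. Any claim that something is new, unique, unknown or untested is made for them only; others in the source may bear on it.

Measured so far:
compound 1 `O=C(Nc1ccc(Cl)cc1)NS(=O)(=O)c1cccs1` — 66%
compound 2 `CCc1ccc(S(=O)(=O)NC(=O)Nc2ccc(Cl)cc2)[nH]1` — 56%

In a functional assay on the whole organism (6C3HED cells, Mus musculus) for inhibition, at a dose of 300 mg/kg by the oral route (on this read-out higher numbers stand for more inhibition at the one dose given (going by the name of the read-out) and lower numbers for less inhibition), compound 2 stands lowest of the two numbers shown, its nearest neighbour being compound 1; the step of a number 10 percentage points lower from compound 1 to compound 2 (within the scatter) lies within the scatter. Compound 3 `Cc1cc(S(=O)(=O)NC(=O)Nc2ccc(Cl)cc2)sc1C` is not yet measured. It differs from compound 2 as follows: 4,5-dimethylthiophen-2-yl in place of 5-ethyl-1H-pyrrol-2-yl on a sulfonyl sulfur. Among the measured compounds shown here, the only step that bears on this change is the one from compound 1 to compound 2, which was within the scatter, so no change beyond the scatter is expected here. Compound 3 is therefore expected to give about 60%, in a range from 35% to 80%, which is estimated to mean a step of a number 4 percentage points higher from compound 2 to compound 3 (within the scatter).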

Compound 3, a percentage reported as inhibition, in the whole organism at one dose (the size of the read-out at that dose, not a potency): 73%
Compound 3: the middle estimate sits 13 percentage points below what was measured; low and high end bracket the measured number.
By their numbers in this assay, from the lowest: compounds 2, 1 and 3 (each within the scatter of the next, the first and the last beyond it).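

In this assay, this position on the sulfonyl sulfur now shows a step beyond the scatter: a number 17 percentage points higher from compound 2 to compound 3 (beyond the scatter) when 4,5-dimethylthiophen-2-yl replaces 5-ethyl-1H-pyrrol-2-yl. Replacing thiophen-2-yl with 4,5-dimethylthiophen-2-yl gives a number 7 percentage points higher from compound 1 to compound 3 (within the scatter), so the dimethyl pattern cannot be read as a real change from the unsubstituted ring. Nothing available explains the difference between these groups. The compounds shown leave open how an amine or a carboxylic acid on the ring would fare. They also leave open whether a longer chain could take the ring's place on the sulfonyl sulfur.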